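The source may hold more compounds than are shown below. What is called first, only, known or untested is meant among the compounds shown, and "the series" means these compounds.

In an ADME assay on MT4 cells (Homo sapiens) for cytotoxicity, read by MTT assay, with a stated time of 5 days (a higher number here means that more compound is tolerated, a lower number that less compound is tolerated), compound 3 `Cc1cc(C)cc(S(=O)(=O)c2c(C(=O)NC3CN(S(C)(=O)=O)C3)[nH]c3ccc(Cl)cc23)c1` gives > 252000 nM, which is a limit and not a number. That places it at the limit of > 252000 nM in this assay, at which 1 of the 3 values shown sits. Compound 1 `Cc1cc(C)cc(S(=O)(=O)c2c(C(N)=O)[nH]c3ccc(Cl)cc23)c1` gives 13000 nM and compound 2 `Cc1cc(C)cc(S(=O)(=O)c2c(C(=O)N[C@H]3CCNC3)[nH]c3ccc(Cl)cc23)c1` gives 10000 nM, and the gap between them is a 1.3-fold lower number from compound 1 to compound 2 (0.11 log units; within the scatter). Two large steps lead to the limit: an at least 19-fold higher number from compound 1 to compound 3 (1.28 log units; beyond the scatter) and an at least 25-fold higher number from compound 2 to compound 3 (1.40 log units; beyond the scatter). Compound 4 `Cc1cc(C)cc(S(=O)(=O)c2c(C(=O)NC3CN(Cc4n[nH]c(=O)n4C)C3)[nH]c3ccc(Cl)cc23)c1` gives up the methylsulfonyl group on an amine nitrogen in a ring: a group of 8 heavy atoms (4 carbon, 3 nitrogen, 1 oxygen; one five-membered aromatic ring with 3 hetero atoms) in place of a group of 4 heavy atoms (1 carbon, 2 oxygen, 1 sulfur; no ring), on an amine nitrogen in a ring. Among the measured compounds shown here, no measured step makes this exchange, so those two large steps are the nearest guide, and a large move to a lower number is expected in this assay. The expected step is an at least 6.3-fold lower number from compound 3 to compound 4 (0.79 log units; beyond the scatter). For compound 4 the estimate is 40000 nM, with an expected range from 10000 nM to 200000 nM.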

Compound 4, half-maximal cytotoxic concentration: 25200 nM
Compound 4: the middle estimate sits 1.6-fold (0.20 log units) above what was measured; low and high end bracket the measured number.
By their numbers in this assay, from the lowest: compounds 2, 1 and 4 (each within the scatter of the next, the first and the last beyond it). At a limit, above all of these: compound 3.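

With the four-membered ring kept, exchanging methylsulfonyl for the larger group with a five-membered aromatic ring gives an at least 10-fold lower number from compound 3 to compound 4 (1.00 log units; beyond the scatter), so the group on this amine nitrogen in a ring matters on its own. Compound 4 also sits close to the compounds without that ring, with a 1.9-fold higher number from compound 1 to compound 4 (0.29 log units; within the scatter) and a 2.5-fold higher number from compound 2 to compound 4 (0.40 log units; beyond the scatter). The step from compound 3 starts from a limit and not a number: the limit of > 252000 nM in this assay, at which 1 of the 4 values shown sits.

The compounds shown leave open whether a free amine or a simple methyl on this nitrogen would stay near compound 4. They also leave open whether other sulfonyl groups, such as ethylsulfonyl, would behave like compound 3.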